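Thiosemicarbazone series: swapping the arylidene unit on compound 2

The source may hold more compounds than are shown below. What is called first, only, known or untested is meant among the compounds shown, and "the series" means these compounds.

Compound 1 `CC1=CC[C@@H]([C@@](C)(O)CCCC(C)(C)NC(=S)NN)CC1` carries the free terminal nitrogen and in a functional assay on K562 cells (Homo sapiens) for cytotoxicity, read by sulforhodamine B assay (a lower number here means a stronger inhibitor of growth, a higher number a weaker inhibitor of growth), compound 1 gives 380 nM. Going by the values given here, compound 2 `CC1=CC[C@@H]([C@@](C)(O)CCCC(C)(C)NC(=S)N/N=C\c2ccccc2Cl)CC1` is its arylidene derivative; in this assay compound 2 gives 4110 nM, the highest of the two numbers measured so far, and the step of an 11-fold higher number from compound 1 to compound 2 (1.03 log units; beyond the scatter) is the only one available in the set.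

Compound 3 `CC1=CC[C@@H]([C@@](C)(O)CCCC(C)(C)NC(=S)N/N=C(/C)c2ccccc2)CC1` differs from compound 2 by a group of 9 heavy atoms (8 carbon, 1 nitrogen; one six-membered aromatic ring of carbon only) in place of a group of 9 heavy atoms (7 carbon, 1 nitrogen, 1 chlorine; one six-membered aromatic ring of carbon only), on an amide-type nitrogen. Among the compounds with values here, no measured pair isolates this exchange: the one step recorded, an 11-fold higher number from compound 1 to compound 2 (1.03 log units; beyond the scatter), concerns the attachment of an arylidene unit to the terminal nitrogen rather than an exchange between two such units, and both compound 2 and compound 3 keep that unit in place. The data therefore give no ground for a move in either direction beyond the scatter, and compound 3 is expected to sit close to compound 2 in this assay.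

On that basis the estimated step of a 1.2-fold lower number from compound 2 to compound 3 (0.07 log units; within the scatter) is expected to be small. Compound 3 is estimated at 3500 nM in this assay, with a range from 1200 nM to 10000 nM.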

Compound 3, concentration for total growth inhibition: 70 nM
The estimate for compound 3 lay 50-fold (1.70 log units) above the measured number; measured number outside the range, below it.
By their numbers in this assay, from the lowest: compound 3; then compound 1; then compound 2.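

In this assay, the place on the amide-type nitrogen whose other neighbour is the thiocarbonyl carbon proves highly sensitive to the identity of the group, even when the count of heavy atoms stays the same: a 59-fold lower number from compound 2 to compound 3 (1.77 log units; beyond the scatter). Replacing the free terminal nitrogen does not lead in one direction, since a 5.4-fold lower number from compound 1 to compound 3 (0.73 log units; beyond the scatter), whereas the chlorine-bearing group of compound 2 went the other way, with an 11-fold higher number from compound 1 to compound 2 (1.03 log units; beyond the scatter); the earlier pair alone had suggested only a loss, and compound 3 now goes against that reading. No supporting data bear on why the two groups differ so widely.

The exchange from compound 2 to compound 3 removes the chlorine and adds a carbon in a single step, so these compounds cannot show which change carries the shift, or whether both contribute. A group holding both the chlorine and the added carbon, and a plain benzylidene group with neither, would separate the two changes, while a pyridine ring in place of the benzene ring would test how far the result depends on the all-carbon aromatic ring.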